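This account rests on a few compounds, and the source may have more. Where it says the series, first, only, none or still open, it means among the compounds named here.

Compound 1 `CC(C(=O)NCc1ccc(C(F)(F)F)cc1N1CCC(C)(C)CC1)c1ccc(NS(C)(=O)=O)c(F)c1`: 1.3 nM
Compound 2 `Cc1ccc(N2CCN(c3cc(C(F)(F)F)ccc3CNC(=O)C(C)c3ccc(NS(C)(=O)=O)c(F)c3)CC2)cc1`: 0.7 nM

Both measured compounds were tested in an assay on CHO cells for antagonist activity at transient receptor potential cation channel subfamily V member 1 (Homo sapiens), read by FLIPR; a higher number here means a weaker inhibitor, a lower number a stronger inhibitor. Compound 1 gives 1.3 nM in this assay, and compound 2 gives 0.7 nM. Compound 1 has the higher of the two numbers, but the gap between them lies within the scatter of repeated measurements, so on this evidence the two compounds cannot be told apart.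

Compound 3 `CC(C(=O)NCc1ccc(C(F)(F)F)cc1OCc1ccccc1)c1ccc(NS(C)(=O)=O)c(F)c1` has not yet been measured. It differs from compound 1 in one place: benzyloxy in place of 4,4-dimethylpiperidin-1-yl on an aromatic carbon. Going by the values given here, nothing measured so far shows what a benzyloxy group does at this position, since neither measured compound carries one, so the expectation rests only on the closeness of the two measured numbers and the size of the exchanged groups, which is the same in heavy atoms. The step is therefore expected to be small and tilted toward a weaker inhibitor, close to the edge of the scatter: a 2.3-fold higher number from compound 1 to compound 3 (0.36 log units; beyond the scatter). Compound 3 is expected to give 3 nM in this assay, with a range from 0.8 nM to 12 nM.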

Compound 3, inhibition constant: 0.9 nM
Estimate against measurement, compound 3: 3.3-fold (0.52 log units) above; low and high end bracket the measured number.
By their numbers in this assay, from the lowest: compounds 2, 3 and 1 (each within the scatter of the next).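

In this assay, putting benzyloxy in place of 4,4-dimethylpiperidin-1-yl gives a 1.4-fold lower number from compound 1 to compound 3 (0.16 log units; within the scatter), so this exchange leaves the two compounds indistinguishable. The position, an aromatic carbon ortho to a large group and meta to a trifluoromethyl group, therefore holds either a six-membered non-aromatic ring containing nitrogen or a six-membered aromatic ring of carbon only, reached through oxygen, with no change beyond the scatter; compound 3 has no nitrogen in this group, so a nitrogen at this place is not required for a value in this range. Nothing measured here explains why these two groups give such similar numbers.

The compounds shown leave open whether a group of this size is needed at all, since a single methoxy group or a bare hydrogen at this position would test that directly. On these data alone, it also remains unknown how this position responds to a primary amine or a carboxylic acid, and whether the aromatic ring of benzyloxy could be replaced by a plain longer carbon chain without changing the number.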